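Replacing Ethyl with 3-Fluorophenyl on a Fused Core

A few compounds are considered here, and "the series" means these few. Any claim that something is new, unique, unknown or untested is made for them only; others in the source may bear on it.

Three compounds sharing one fused core have been examined in an assay for inhibition of histone-lysine N-methyltransferase, H3 lysine-79 specific (Homo sapiens), with stated times of 15 min and 120 min, tested at 50 uM; a higher number here means more inhibition at the concentration tested (going by the name of the read-out), a lower number less inhibition. Compound 1 `CCc1nnc2sc(-c3cccc(F)c3)nn12` gives 13%. Compound 2 `Fc1cccc(-c2nn3c(CCc4ccccc4)nnc3s2)c1` gives 18%, and compound 3 `Fc1cccc(-c2nn3c(Cc4ccccc4F)nnc3s2)c1` gives 25%. Compound 1 carries the lowest of the three numbers: its nearest neighbour is compound 2, with a number 5 percentage points higher from compound 1 to compound 2 (within the scatter), and the widest gap is to compound 3, with a number 12 percentage points higher from compound 1 to compound 3 (beyond the scatter). Between the two larger analogues the difference is a number 7 percentage points higher from compound 2 to compound 3 (within the scatter).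

Compound 4 `Fc1cccc(-c2nn3c(-c4cccc(F)c4)nnc3s2)c1` is the next structure to be measured in this assay. It differs from compound 1 in one respect: 3-fluorophenyl in place of ethyl on an aromatic carbon. The three measured steps all alter this same substituent on the core, and each enlargement of it moved the number upward by a small amount, once within the scatter and once modestly beyond it. None of them, however, placed an aromatic ring directly on the core carbon; in compounds 2 and 3 the ring hangs from a saturated chain. On that basis a small rise is expected for compound 4, on the order of a number 12 percentage points higher from compound 1 to compound 4 (beyond the scatter). Compound 4 is therefore estimated at 25%, with a range from 8% to 45%.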

Compound 4, a percentage reported as inhibition, at one concentration (the size of the read-out at that concentration, not a potency): 11%
Beside the measured number, compound 4's estimate is 14 percentage points above it; the measured number falls inside the stated range.
By their numbers in this assay, from the lowest: compounds 4, 1, 2 and 3 (each within the scatter of the next, the first and the last beyond it).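

Putting an aromatic ring directly on the core carbon gives no separation from ethyl in this assay: the step is a number 2 percentage points lower from compound 1 to compound 4 (within the scatter), even though 3-fluorophenyl brings more heavy atoms and a six-membered aromatic ring to this position. The earlier compounds carried their rings only on a saturated chain, and here compound 3 gives 25% while compound 4 gives 11%, so among these compounds an aromatic ring in this substituent does not by itself go with a higher number. Nothing available here explains why the directly attached ring fails to raise the reading.

Going by these compounds, what stays open is whether the fluorine of the entering group matters at all, which a plain phenyl or a 2-fluorophenyl on the same aromatic carbon would test. On these data alone, it is also open whether a ring bearing an amine or a carboxylic acid, or a longer alkyl chain with no ring, would move the number at this position clearly away from the low readings seen so far.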